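From compound 3 to compound 4: bromo to iodo

This account rests on a few compounds, and the source may have more. Where it says the series, first, only, none or still open, it means among the compounds named here.

In a functional assay on SK-OV-3 cells (Homo sapiens) for antiproliferative activity, read by MTT assay, with a stated time of 72 h (on this read-out lower numbers stand for stronger inhibition and higher numbers for weaker inhibition), compound 1 `O=C(CCc1cccc2c1B(O)OC2)Nc1ccc(Br)cc1` gives 9200 nM, compound 2 `Cc1ccc(NC(=O)CCc2cccc3c2B(O)OC3)cc1` gives 860 nM and compound 3 `O=C(CCc1cccc2c1B(O)OC2)Nc1cccc(Br)c1` gives 540 nM. Compound 3 has one close neighbour, with a 1.6-fold lower number from compound 2 to compound 3 (0.20 log units; within the scatter), and lies far from the third value, with a 17-fold lower number from compound 1 to compound 3 (1.23 log units; beyond the scatter).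

Compound 4 `O=C(CCc1cccc2c1B(O)OC2)Nc1cccc(I)c1` carries iodo in place of bromo on an aromatic carbon, meta to a large group. Among the measured compounds shown here, no measured step exchanges one halogen for another at this place. The large steps, an 11-fold lower number from compound 1 to compound 2 (1.03 log units; beyond the scatter) and a 17-fold lower number from compound 1 to compound 3 (1.23 log units; beyond the scatter), both leave the 4-bromophenyl compound. For the measured compounds named here, the only step between compounds without it is small.

In this assay, going by the values given here, the expected change is a 1.1-fold lower number from compound 3 to compound 4 (0.03 log units; within the scatter), with no step expected beyond the scatter. For compound 4 the estimate is 500 nM, within an expected range of 200 nM to 1300 nM.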

Compound 4, half-maximal inhibitory concentration: 630 nM
Estimate against measurement, compound 4: 1.3-fold (0.10 log units) below; low and high end bracket the measured number.
By their numbers in this assay, from the lowest: compounds 3, 4 and 2 (each within the scatter of the next); then compound 1.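

In this assay, iodo in place of bromo meta to a large group gives a 1.2-fold higher number from compound 3 to compound 4 (0.07 log units; within the scatter) in the first halogen exchange seen at this place. The 3-iodophenyl group gives a 1.4-fold lower number from compound 2 to compound 4 (0.14 log units; within the scatter) against the 4-methylphenyl group and a 15-fold lower number from compound 1 to compound 4 (1.16 log units; beyond the scatter) against the 4-bromophenyl group, which leaves compound 1 alone at the weak end of the series. No available evidence bears on these results.

From the compounds shown here alone, whether chloro, fluoro, an amine or a carboxylic acid at this place would stay within the scatter of compound 3 remains open. So does the effect of a 4-iodophenyl group.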